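Swapping a Propargyl Ether for a Methoxybenzoate Ester

A few compounds are considered here, and "the series" means these few. Any claim that something is new, unique, unknown or untested is made for them only; others in the source may bear on it.

Compound 1 `C#CCOc1cc(/C=C/C(=O)c2ccc(OC)c3c2OC(C)(C)C=C3)ccc1OC` was tested in an ADME assay on L02 cells (Homo sapiens) for cytotoxicity, read by MTT assay; on this read-out higher numbers stand for weaker inhibition and lower numbers for stronger inhibition. In this assay compound 1 gives > 10000 nM, which is a limit of the assay and not a number. Compound 2 `COc1ccc(/C=C/C(=O)c2ccc(OC)c3c2OC(C)(C)C=C3)cc1OC(=O)CCl` likewise gives only a limit in this assay, namely > 10000 nM. Within the data shown here, the single measured step, a step that the two limits leave unreadable from compound 1 to compound 2, is unreadable because of the limit of > 10000 nM in this assay, at which 2 of the 2 values shown sit. Compound 3 `COc1cccc(C(=O)Oc2cc(/C=C/C(=O)c3ccc(OC)c4c3OC(C)(C)C=C4)ccc2OC)c1` differs from compound 1 by (3-methoxyphenyl)carbonyl in place of propargyl on an oxygen on an aromatic ring. Nothing measured here points toward stronger inhibition, so compound 3 is expected to stay at the limit again, a step that the limit leaves unreadable from compound 1 to compound 3. The estimate for compound 3 is 15000 nM, within 5000 nM to 50000 nM.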

Compound 3, half-maximal inhibitory concentration: > 10000 nM
Compound 3: no number, only a limit; the forecaster's own chance of this, stated with the estimate: 75%; the middle value does not contradict the limit.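

Compound 3 also gives only a limit, so its steps from compound 1 and compound 2 cannot be read, because all three compounds sit at the same limit: the limit of > 10000 nM in this assay, at which 3 of the 3 values shown sit.

On these data alone, how strongly compound 1, compound 2 and compound 3 inhibit in this assay stays open, as does whether their different groups on that oxygen change anything.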